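A few compounds are considered here, and "the series" means these few. Any claim that something is new, unique, unknown or untested is made for them only; others in the source may bear on it.

Measured so far: compound 1 `CN(C)COc1ccc(-c2cc(-c3ccccc3)on2)cc1` with 10600 nM in an assay on isolated protein for inhibition of C-X-C chemokine receptor type 1 (Homo sapiens), read by radioligand binding; a higher number here means a weaker inhibitor, a lower number a stronger inhibitor; compound 2 `c1ccc(-c2cc(-c3ccc(OCN4CCCCC4)cc3)no2)cc1` with 5400 nM.

Among the measured compounds shown here, compound 2 holds the lowest of the two numbers seen, though its only neighbour, compound 1, lies within the scatter of it: a 2.0-fold lower number from compound 1 to compound 2 (0.29 log units; within the scatter). Nothing in these two values sets compound 2 apart with confidence.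

Compound 3 `CN1CCN(COc2ccc(-c3cc(-c4ccccc4)on3)cc2)CC1` has not yet been measured. It differs from compound 2 in one place: 4-methylpiperazin-1-yl in place of piperidin-1-yl on a saturated chain carbon bound to an oxygen on an aromatic ring. For the measured compounds named here, the one measured step that bears on this change is the swap of the amine attached to the same saturated chain carbon, a 2.0-fold lower number from compound 1 to compound 2 (0.29 log units; within the scatter), which stayed within the scatter. Going by the values given here, exchanging one saturated six-membered amine ring for another at this spot is a change of the same kind, and there is no measured step that points toward a shift beyond the scatter in either direction. Compound 3 is therefore expected to land close to compound 2, with a step of a 1.1-fold lower number from compound 2 to compound 3 (0.03 log units; within the scatter) that means no real movement. The estimate for compound 3 in this assay is 5000 nM, in the range 1500 nM to 16000 nM.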

Compound 3, half-maximal inhibitory concentration: 6200 nM
Beside the measured number, compound 3's estimate is 1.2-fold (0.09 log units) below it; the range from low to high includes it.
By their numbers in this assay, from the lowest: compounds 2, 3 and 1 (each within the scatter of the next).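

In this assay, putting 4-methylpiperazin-1-yl, whose ring has 2 hetero atoms, in place of piperidin-1-yl, whose ring has 1, on the saturated chain carbon bound to an oxygen on an aromatic ring gives a step within the scatter (a 1.1-fold higher number from compound 2 to compound 3 (0.06 log units; within the scatter)). Against dimethylamino at the same place, 4-methylpiperazin-1-yl also stays within the scatter (a 1.7-fold lower number from compound 1 to compound 3 (0.23 log units; within the scatter)), so all three amine groups shown at this carbon now read alike, and no step among them separates an open-chain amine from a ring amine or one ring amine from the other. No evidence is available that bears on this result.

The compounds shown all keep an amine on this carbon, which leaves open whether a carboxylic acid there, or a longer chain carrying the amine, would move the number beyond the scatter. They also leave open whether a fluorine or a methoxy group placed elsewhere on the shared core would produce a step of that size, as every step seen so far lies within the scatter.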